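The source may report more compounds than this note shows. Statements on the series, on what has been measured and on what is new or still open speak of the compounds shown alone.

Measured in a functional assay on MC-38 cells (Mus musculus) for antiproliferative activity, read by CCK-8 assay, with a stated time of 48 h; on this read-out lower numbers stand for stronger inhibition and higher numbers for weaker inhibition:
- Compound 1 `COc1ccc(/C=C\c2cc(OC)c(OC)c(OC)c2)cc1OCc1ccc(CN2C[C@H](O)C[C@@H]2C(=O)O)cc1`: > 10000 nM (a limit)
- Compound 2 `COc1ccc(/C=C\c2cc(OC)c(OC)c(OC)c2)cc1OCc1ccc(CN2CC[C@H](C(=O)O)C2)cc1`: > 10000 nM (a limit)
- Compound 3 `COc1ccc(/C=C\c2cc(OC)c(OC)c(OC)c2)cc1OCc1ccc(CNCCN(C)C)cc1`: 1400 nM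

Compound 3 stands alone here with an actual number, 1400 nM. Compound 4 `COc1ccc(/C=C\c2cc(OC)c(OC)c(OC)c2)cc1OCc1ccc(CN[C@H](C(=O)O)[C@@H](C)O)cc1` differs from it as follows: 1-carboxy-2-hydroxypropyl in place of 2-(dimethylamino)ethyl on an amine nitrogen. Going by the values given here, the steps that bear on this run the opposite way, and both install (2-(dimethylamino)ethyl)amino in place of a carboxy-bearing ring: an at least 7.1-fold lower number from compound 1 to compound 3 (0.85 log units; beyond the scatter), and an at least 7.1-fold lower number from compound 2 to compound 3 (0.85 log units; beyond the scatter). Compound 4 brings a carboxy group back, so a reversal to a higher number of at least modest size is expected, towards (the limit of > 10000 nM in this assay, at which 2 of the 3 values shown sit). The expected change is a 7.9-fold higher number from compound 3 to compound 4 (0.90 log units; beyond the scatter). For compound 4 the estimate is 11000 nM, with an expected range of 4000 nM to 30000 nM.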

Compound 4, half-maximal inhibitory concentration: > 10000 nM
Compound 4 ended at the assay's limit; the forecaster's own chance of this, stated with the estimate: 70%; the middle value does not contradict the limit.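

In this assay, the change on this amine nitrogen gives an at least 7.1-fold higher number from compound 3 to compound 4 (0.85 log units; beyond the scatter). The carboxy-bearing groups seen earlier at this place were rings, whereas 1-carboxy-2-hydroxypropyl has no ring, and compound 4 still ends at a limit of the assay: the limit of > 10000 nM in this assay, at which 3 of the 4 values shown sit. The steps among compound 1, compound 2 and compound 4 cannot be read, as all three values are limits.

Compound 4 gains a carboxylic acid and loses the dimethylamino group in one change, and the compounds shown leave open which of the two matters. Nor do they show how a hydroxyalkyl chain without the carboxylic acid, or a longer chain ending in dimethylamino, would behave.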